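The compounds below may be only part of what the source reports. "The series", "measured", "known", "first", "only" and "open" are said of these compounds alone.

Compound 1 `CNC(=O)c1cc(C(=O)NCCCC2CNCCO2)cn(Cc2ccccc2)c1=O` carries a 3-(morpholin-2-yl)propyl group on its amide-type nitrogen and a benzyl group on the shared core. In a physicochemical assay for solubility (on this read-out lower numbers stand for lower solubility and higher numbers for higher solubility), compound 1 returns only a limit of the assay, >= 194 ug/mL. Compound 2 `CNC(=O)c1cc(C(=O)NC2CC2)cn(CC2CCOCC2)c1=O`, which pairs a cyclopropyl amide with an oxan-4-ylmethyl group on the core, likewise returns a limit in this assay, >= 165 ug/mL. Both readings are limits, so neither compound can be placed above the other: compound 1 sits at the limit of >= 194 ug/mL in this assay, at which 1 of the 2 values shown sits, and compound 2 at the limit of >= 165 ug/mL in this assay, at which 1 of the 2 values shown sits, and nothing more can be said of their order. Among the compounds with values here, no two measured compounds differ in a single place, so no measured step is available.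

Compound 3 `CNC(=O)c1cc(C(=O)NC2CCOCC2)cn(Cc2ccccc2)c1=O` is not yet measured. It differs from compound 1 by oxan-4-yl in place of 3-(morpholin-2-yl)propyl on an amide-type nitrogen. Within the data shown here, with no measured step to lean on, the expectation rests on the two limits alone. The expected step is an at least 2.4-fold lower number from compound 1 to compound 3 (0.38 log units; beyond the scatter), a move toward lower solubility, though the reading may once more stop at a limit. Compound 3 is estimated at 80 ug/mL, within a range from 20 ug/mL to 200 ug/mL in this assay.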

Compound 3, solubility: >= 174 ug/mL
Compound 3: no number, only a limit (the forecaster's own chance of this, stated with the estimate: 30%); middle value at least 2.1-fold (0.33 log units) away from the limit.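

Compound 1 and compound 3 both stop at a limit in this assay, so no step can be read between them, and oxan-4-yl in place of 3-(morpholin-2-yl)propyl has no readable size. The compounds shown leave open what number each would take in this assay and how the three would order.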